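Swapping the aryl group on the sulfonyl sulfur

The source may hold more compounds than are shown below. What is called first, only, known or untested is meant among the compounds shown, and "the series" means these compounds.

Measured so far in a functional assay on A2780 cells (Homo sapiens) for cytotoxicity, read by sulforhodamine B assay, with a stated time of 72 h; a lower number here means a stronger inhibitor, a higher number a weaker inhibitor:
compound 1 `O=C(NCc1ccc(S(=O)(=O)c2ccccc2)cc1)N1Cc2cccnc2C1`: > 2000 nM (a limit)
compound 2 `O=C(NCc1ccc(S(=O)(=O)c2cccc(C(F)(F)F)c2)cc1)N1Cc2ccncc2C1`: 2.7 nM

Within the data shown here, compound 2 holds the only actual number in this assay, at 2.7 nM. Compound 1 is reported as > 2000 nM, which is a limit and not a number.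

The next structure is compound 3 `CC(C)n1cc(S(=O)(=O)c2ccc(CNC(=O)N3Cc4ccncc4C3)cc2)cn1`, with 1-isopropyl-1H-pyrazol-4-yl in place of 3-(trifluoromethyl)phenyl on a sulfonyl sulfur. Among the measured compounds shown here, no measured step shows what such an exchange does in this assay. The expectation therefore starts from compound 2 at 2.7 nM and leans towards a moderate weakening, though a change within the usual scatter remains possible. The expected change is a 3.7-fold higher number from compound 2 to compound 3 (0.57 log units; beyond the scatter). For compound 3 the estimated value is 10 nM, with an expected range of 2 nM to 60 nM.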

Compound 3, half-maximal inhibitory concentration: 11 nM
Beside the measured number, compound 3's estimate is 1.1-fold (0.04 log units) below it, within the range that was stated.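

In this assay, among these compounds, the exchange on the sulfonyl sulfur can now be read for the first time: 1-isopropyl-1H-pyrazol-4-yl in place of 3-(trifluoromethyl)phenyl gives a 4.1-fold higher number from compound 2 to compound 3 (0.61 log units; beyond the scatter). The step is modest, so for this pair a five-membered aromatic ring with 2 hetero atoms can replace a six-membered aromatic ring of carbon only, and compound 3 still gives a measured 11 nM. Nothing measured here accounts for the size of this step.

From the compounds shown here alone, it remains open whether the step belongs to the pyrazole ring itself or to its isopropyl group. A pyrazole with methyl in place of isopropyl, or a pyridine ring on the sulfonyl sulfur, would help to separate the two.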